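Ethylcarbamoyl to isopropylcarbamoyl on the thiophene-bearing core

The source may hold more compounds than are shown below. What is called first, only, known or untested is meant among the compounds shown, and "the series" means these compounds.

Compound 1 `CCNC(=O)C1=C(C)NC(=O)NC1c1ccco1` gives 2% in an assay on membranes from CHO cells for displacement of a labelled ligand from adenosine receptor A1 (Homo sapiens), read by scintillation counting, with a stated time of 60 min, tested at 1 uM; a higher number here means more inhibition at the concentration tested (going by the name of the read-out), a lower number less inhibition. Compound 2 `CC1=C(C(=O)NC(C)C)C(c2ccco2)NC(=O)N1` carries methyl in place of hydrogen on a saturated chain carbon bound to an amide-type nitrogen and a saturated chain carbon and gives 3% in this assay; the step reads a number 1 percentage points higher from compound 1 to compound 2 (within the scatter). Compound 3 `CCNC(=O)C1=C(C)NC(=O)NC1c1ccsc1` gives 3% in this assay and differs from compound 1 by thiophen-3-yl in place of furan-2-yl on a saturated ring carbon, a step of a number 1 percentage points higher from compound 1 to compound 3 (within the scatter). Among the compounds with values here, no step is broken down between compound 2 and compound 3; their two values sit within the scatter of each other.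

Compound 4 `CC1=C(C(=O)NC(C)C)C(c2ccsc2)NC(=O)N1` is not yet measured in this assay. It differs from compound 3 by methyl in place of hydrogen on a saturated chain carbon bound to an amide-type nitrogen and a saturated chain carbon, which is the same change as that from compound 1 to compound 2, made here on the core of compound 3; the two cores differ as told by the thiophen-3-yl for furan-2-yl exchange above. Within the data shown here, all three measured values lie near the floor of the read-out, and the one measured instance of this change, a number 1 percentage points higher from compound 1 to compound 2 (within the scatter), stayed within the scatter. The step from compound 3 to compound 4 is therefore expected to be small, no change at the digits printed from compound 3 to compound 4 (within the scatter), because a number 1 percentage points higher from compound 1 to compound 2 (within the scatter). Compound 4 is estimated at 3%, with a range from -6% to 12%.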

Compound 4, a percentage reported as inhibition, at one concentration (the size of the read-out at that concentration, not a potency): 8%
Beside the measured number, compound 4's estimate is 5 percentage points below it; the measured number falls inside the stated range.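

In this assay, ethylcarbamoyl to isopropylcarbamoyl on the core of compound 3 gives a number 5 percentage points higher from compound 3 to compound 4 (within the scatter), and the two readings of this change do not separate: the same change on two cores in this assay, a number 1 percentage points higher (within the scatter) from compound 1 to compound 2 and a number 5 percentage points higher (within the scatter) from compound 3 to compound 4, 4 percentage points apart, within the scatter of two such steps

The exchange of furan-2-yl for thiophen-3-yl, read on the isopropylcarbamoyl compounds, gives a number 5 percentage points higher from compound 2 to compound 4 (within the scatter), and it too reads alike on both cores: the same change on two cores in this assay, a number 1 percentage points higher (within the scatter) from compound 1 to compound 3 and a number 5 percentage points higher (within the scatter) from compound 2 to compound 4, 4 percentage points apart, within the scatter of two such steps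

Within the data shown here, with all four values low in the read-out, this shows only that neither change moves inhibition beyond the scatter on these cores; it does not show how either change would carry over to a core with clearly measurable inhibition.

The compounds shown leave open whether a longer chain or a benzyl group in place of isopropyl would give a step beyond the scatter. The same question stands for a phenyl group in place of thiophen-3-yl.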